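Methyl to methoxy on the pendant aryl: two cores compared

The compounds below may be only part of what the source reports. "The series", "measured", "known", "first", "only" and "open" are said of these compounds alone.

The series shares an amide-bearing bicyclic core carrying a para-substituted phenyl group and a biaryl arm, and is read in a functional assay on A-375 cells (Homo sapiens) for antiproliferative activity, read by MTT assay, with a stated time of 72 h; on this read-out lower numbers stand for stronger inhibition and higher numbers for weaker inhibition. Compound 1 `COc1ccc(N2C(=O)COc3ccc(-c4cnc(Cl)c(NS(=O)(=O)c5ccc(F)cc5)c4)cc32)cc1` gives 32700 nM. Compound 3 `Cc1ccc(N2C(=O)COc3ccc(-c4cnc(Cl)c(NS(=O)(=O)c5ccc(F)cc5)c4)cc32)cc1` gives 38900 nM. Compound 2 `Cc1ccc(N2C(=O)COc3ccc(-c4cnc5ccccc5c4)cc32)cc1` reaches only the limit > 40000 nM of this assay, so no number is known for it (the limit of > 40000 nM in this assay, at which 1 of the 3 values shown sits). Compound 4 `COc1ccc(N2C(=O)COc3ccc(-c4cnc5ccccc5c4)cc32)cc1` has not yet been measured in this assay.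

The difference between the two cores, that of compound 2 and that of compound 3, is not broken down here. Within the first core the change from compound 3 to compound 1 is methoxy in place of methyl on an aromatic carbon, and it moved the value by a 1.2-fold lower number from compound 3 to compound 1 (0.08 log units; within the scatter), which is within the scatter. The change from compound 2 to compound 4 is methoxy in place of methyl on an aromatic carbon, the same change on the other core, occurring twice in all among the compounds shown.

Given that the measured instance of this change left the number essentially unmoved, compound 4 is expected to sit close to compound 2, with a step that the limit leaves unreadable from compound 2 to compound 4 estimated from compound 2, resting on the step of a 1.2-fold lower number from compound 3 to compound 1 (0.08 log units; within the scatter). Compound 4 is therefore estimated at 45000 nM, with a likely range from 20000 nM to 100000 nM, and a real chance that this assay again reports only a limit for it.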

Compound 4, half-maximal inhibitory concentration: > 40000 nM
Compound 4 gave a limit, no number; the forecaster's own chance of this, stated with the estimate: 65%; the middle value does not contradict the limit.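

Compound 2 and compound 4 each return only a limit, not a number, in this assay, so no step can be read between them: the limit of > 40000 nM in this assay, at which 2 of the 4 values shown sit.

The compounds shown leave open whether 4-methylphenyl to 4-methoxyphenyl changes the value at all on the core of compound 2, and how far the true values of compound 2 and compound 4 lie past the limit.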